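Cyclopropylamino to Anilino on a Shared Core

This account rests on a few compounds, and the source may have more. Where it says the series, first, only, none or still open, it means among the compounds named here.

Compound 3 `O=C(Nc1ccccc1)Nc1nc(NC2CC2)cc(Sc2c[nH]c3ccccc23)n1` is one of three compounds tested in a functional assay on A549 cells (Homo sapiens) for inhibition, with a stated time of 72 h; on this read-out lower numbers stand for stronger inhibition and higher numbers for weaker inhibition. For compound 3 the read-out gives only a limit, > 50000 nM, as noted in the limit of > 50000 nM in this assay, at which 1 of the 3 values shown sits. Compound 1 `COc1ccc(NC(=O)Nc2nc(Sc3c[nH]c4ccccc34)cc(N3CCCCC3)n2)cc1` gives 13500 nM, and compound 2 `Cc1ccc(C)c(NC(=O)Nc2nc(Sc3c[nH]c4ccccc34)cc(N3CCCCC3)n2)c1` gives 25400 nM; the step of a 1.9-fold higher number from compound 1 to compound 2 (0.27 log units; within the scatter) alters the group on the amide-type nitrogen, not the place changed here, so it does not bear directly on the question. Compound 4 `O=C(Nc1ccccc1)Nc1nc(Nc2ccccc2)cc(Sc2c[nH]c3ccccc23)n1` differs from compound 3 by phenyl in place of cyclopropyl on a nitrogen on an aromatic ring. Among the measured compounds shown here, no measured step covers this change, and compound 3 itself supplies only a limit, so the expectation rests on little. Compound 4 is expected to stay weak, with an estimated 40000 nM (range 10000 nM to 150000 nM), which amounts to an expected at least 1.2-fold lower number from compound 3 to compound 4 (0.09 log units; that floor lies within the scatter).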

Compound 4, half-maximal inhibitory concentration: > 50000 nM
Compound 4 was reported as a limit (the forecaster's own chance of this, stated with the estimate: 50%); middle value at least 1.2-fold (0.09 log units) from the limit.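

Compound 3 and compound 4 are both reported only as limits, so the change between them cannot be read as a step: the limit of > 50000 nM in this assay, at which 2 of the 4 values shown sit.

On these data alone, whether phenyl or cyclopropyl on that nitrogen gives stronger inhibition stays open.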